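Swapping Chloro for Methyl on a Weak Inhibitor

The compounds below may be only part of what the source reports. "The series", "measured", "known", "first", "only" and "open" are said of these compounds alone.

Of the compounds shown here, three have so far been measured in a functional assay on SK-N-SH cells (Homo sapiens) for inhibition, read by sulforhodamine B assay, with a stated time of 48 h; a lower number here means a stronger inhibitor, a higher number a weaker inhibitor. Compound 1 `CO[C@@H]1CC=C2NN(c3cc(Cl)cc(Cl)c3)C(=O)C[C@]2(C)O1` gives 20200 nM, compound 2 `COc1ccc(N2NC3=CC[C@@H](OC)O[C@@]3(c3ccccc3)CC2=O)cc1` gives 10400 nM, and compound 3 `CO[C@@H]1CC=C2NN(c3ccc(Cl)cc3)C(=O)C[C@]2(C)O1` gives 31700 nM. Compound 3 thus stands at the highest of the three numbers; its number sits close to that of compound 1, within the scatter, whereas the number of compound 2 lies lower, beyond the scatter.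

Compound 4 `CO[C@@H]1CC=C2NN(c3ccc(C)cc3)C(=O)C[C@]2(C)O1` has not yet been measured. It differs from compound 3 in one place: methyl in place of chloro on an aromatic carbon, a methyl in place of a chloro on an aromatic carbon of a six-membered aromatic ring of carbon only, which one bond further out reads as 4-chlorophenyl to 4-methylphenyl. Among the measured compounds shown here, no pair of measured compounds differs in just this way, so there is no measured step to lean on. All three numbers lie in the weak range, and the two compounds that share the core of compound 3 sit close together, so the expected step of a 1.1-fold lower number from compound 3 to compound 4 (0.02 log units; within the scatter) in this assay is small, with no clear direction and none beyond the scatter. Compound 4 is therefore estimated at 30000 nM, within a range from 10000 nM to 90000 nM.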

Compound 4, half-maximal inhibitory concentration: 25300 nM
The estimate for compound 4 lay 1.2-fold (0.07 log units) above the measured number; measured number inside the range.
By their numbers in this assay, from the lowest: compounds 2, 1, 4 and 3 (each within the scatter of the next, the first and the last beyond it).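

In this assay the exchange of chloro for methyl gives a 1.3-fold lower number from compound 3 to compound 4 (0.10 log units; within the scatter) and so does not separate the two groups at this place on the six-membered aromatic ring. Among the compounds shown here, this is the first step that can be read for a single change, and it shows that a chloro and a methyl, each a single heavy atom with no hydrogen-bond donors or acceptors, give numbers that cannot be told apart here, with both compounds remaining in the weak range. No measurement at hand says why the two groups read alike.

The compounds shown leave open whether a group of a different kind at this same place, such as an amine, a carboxylic acid or a longer chain, would shift the number beyond the scatter or leave it as flat as this step does. For the compounds shown here, they also leave open whether the exchange of chloro for methyl would read the same way on another core, since the only step available for it lies on the core of compound 3.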